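Moving a Fluorine Around the Phenyl Ring

The compounds below may be only part of what the source reports. "The series", "measured", "known", "first", "only" and "open" are said of these compounds alone.

Of the compounds shown here, three have been measured in a functional assay on HL-60 cells (Homo sapiens) for inhibition, read by MTT assay, with a stated time of 72 h; a higher number here means a weaker inhibitor, a lower number a stronger inhibitor. Compound 1 `COc1cc(OC)cc(N2CCN(C(=O)c3onc(C)c3-c3ccccc3F)CC2)c1` gives 165 nM. Compound 2 `COc1cc(OC)cc(N2CCN(C(=O)c3onc(C)c3-c3ccc(F)cc3)CC2)c1` gives 475 nM. Compound 3 `CCc1nc(-c2ccc(F)cc2)c(C(=O)N2CCN(c3cccc(OC)c3)CC2)o1` gives 411 nM. Compounds 1 and 2 share a core that differs from the core of compound 3, and that difference between the two cores is not broken down here.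

Between compound 2 and compound 1 the only change is 2-fluorophenyl in place of 4-fluorophenyl on an aromatic carbon and it produced a 2.9-fold lower number from compound 2 to compound 1 (0.46 log units; beyond the scatter). The unmeasured compound 4 `CCc1nc(-c2ccccc2F)c(C(=O)N2CCN(c3cccc(OC)c3)CC2)o1` carries the same kind of change relative to compound 3: 2-fluorophenyl in place of 4-fluorophenyl on an aromatic carbon. The surroundings are not identical, though. In compound 1 the changed carbon sits next to the ring atom that bears a methyl group and two ring bonds from the ring nitrogen, whereas in compound 4 it sits next to the ring nitrogen and two ring bonds from the ring atom that bears an ethyl group.

Because the change gave a 2.9-fold lower number from compound 2 to compound 1 (0.46 log units; beyond the scatter), a similar but somewhat smaller step is expected, roughly a 2.2-fold lower number from compound 3 to compound 4 (0.34 log units; beyond the scatter). Compound 4 is therefore estimated at 190 nM, plausibly between 70 nM and 500 nM.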

Compound 4, half-maximal inhibitory concentration: 607 nM
The estimate for compound 4 lay 3.2-fold (0.50 log units) below the measured number; measured number outside the range, above it.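

In this assay, putting 2-fluorophenyl in place of 4-fluorophenyl on the second core gives a 1.5-fold higher number from compound 3 to compound 4 (0.17 log units; within the scatter), so compounds 3 and 4 cannot be told apart on this measure. The clear gain seen on the first core therefore did not carry over, and the two outcomes genuinely differ: the same change on two cores in this assay, a 2.9-fold lower number (0.46 log units; beyond the scatter) from compound 2 to compound 1 and a 1.5-fold higher number (0.17 log units; within the scatter) from compound 3 to compound 4, 4.3-fold (0.63 log units) apart, beyond the scatter of two such steps This shows that, for these two cores, the result of moving the fluorine depends on the core that carries it, but it does not show which part of the core matters, and a single pair on each core gives no general rule for the series.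

On these data alone, it remains open whether a 2-chlorophenyl group or a plain phenyl group would show the same split between the two cores. Also unresolved is which of the structural differences between the cores decides whether the swap from 4-fluorophenyl to 2-fluorophenyl lowers the number.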